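A few compounds are considered here, and "the series" means these few. Any claim that something is new, unique, unknown or untested is made for them only; others in the source may bear on it.

In a functional assay on HeLa cells (Homo sapiens) for antiproliferative activity, read by MTT assay, with a stated time of 48 h (on this read-out lower numbers stand for stronger inhibition and higher numbers for weaker inhibition), compound 1, `CNCC(=O)Nc1cc(OC)ccc1C(=O)c1ccc2c(c1)C=CC(C)(C)O2`, gives 970 nM. Compound 2, `CCNCC(=O)Nc1cc(OC)ccc1C(=O)c1ccc2c(c1)C=CC(C)(C)O2`, carries one alteration on this core, (methyl in place of hydrogen on a saturated chain carbon bound to an amine nitrogen), and in this assay compound 2 gives 3110 nM. The step, a 3.2-fold higher number from compound 1 to compound 2 (0.51 log units; beyond the scatter), lies beyond the usual scatter, so this substitution weakened the antiproliferative effect on the first core.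

Compound 3, `C=C(c1ccc2c(c1)C=CC(C)(C)O2)c1ccc(OC)cc1NC(=O)CNC`, rests on a different core; how its core differs from that of compound 1 is not broken down here. In this assay compound 3 gives 410 nM, the lowest of the three numbers, standing beyond the scatter from compound 1 and further still from compound 2.

Compound 4, `C=C(c1ccc2c(c1)C=CC(C)(C)O2)c1ccc(OC)cc1NC(=O)CNCC`, has not yet been measured. It differs from compound 3 by methyl in place of hydrogen on a saturated chain carbon bound to an amine nitrogen, which is the same change that turns compound 1 into compound 2, made on the same kind of position. Among the compounds shown the change occurs twice in all, with only one measured step to go by. The expectation for compound 4 therefore rests on compound 1 and compound 2, whose step a 3.2-fold higher number from compound 1 to compound 2 (0.51 log units; beyond the scatter) was modest but clear. Compound 4 is expected to give a weaker result than compound 3 by a step of about a 3.2-fold higher number from compound 3 to compound 4 (0.50 log units; beyond the scatter), with the estimate for compound 4 placed at 1300 nM and a likely range from 600 nM to 3000 nM.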

Compound 4, half-maximal inhibitory concentration: 1580 nM
Compound 4: the middle estimate sits 1.2-fold (0.08 log units) below what was measured, and the stated range covers the measured number.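

In this assay, the change from methylamino to ethylamino on the second core again gives a weaker result, with a 3.9-fold higher number from compound 3 to compound 4 (0.59 log units; beyond the scatter). Set beside the earlier step, the change carries over from one core to the other at much the same size: the same change on two cores in this assay, a 3.2-fold higher number (0.51 log units; beyond the scatter) from compound 1 to compound 2 and a 3.9-fold higher number (0.59 log units; beyond the scatter) from compound 3 to compound 4, 1.2-fold (0.08 log units) apart, within the scatter of two such steps. Among these compounds, this shows that the change behaved alike on these two cores in this one assay, but with only two pairs it does not show that it would do so on a further core, and these data do not tell why the number rises.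

The compounds shown stop at the ethylamino group, so it remains open how a longer chain such as propylamino, a branched chain such as isopropylamino, a cyclic amine such as pyrrolidine or a primary amine would fare on either core. Also open, going by these compounds, is whether the step between the methylamino and ethylamino compounds would hold in another cell line.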